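The source may hold more compounds than are shown below. What is called first, only, known or untested is meant among the compounds shown, and "the series" means these compounds.

Compound 1 `CCN(CC)C(=O)c1ccc(-c2cc(C3=CC(=O)C=CC3=O)no2)s1` gives 8900 nM in a functional assay on PC-3 cells (Homo sapiens) for cytotoxicity, read by XTT assay, with a stated time of 72 h; on this read-out lower numbers stand for stronger inhibition and higher numbers for weaker inhibition. Compound 2 `O=C1C=CC(=O)C(c2cc(-c3ccc(C(=O)N4CCCC4)s3)on2)=C1` reaches only a limit of the assay in this assay, < 30000 nM. For the measured compounds named here, the step that the limit leaves unreadable from compound 1 to compound 2 consequently has no readable size, though it is the one change at the carbonyl carbon in the measured set. Compound 3 `COc1ccc(OC)c(-c2cc(-c3ccc(C(=O)NCC4CC4)s3)on2)c1` also sits at a limit in this assay, > 30000 nM, so compound 3 has no number to stand on. Compound 4 `COc1ccc(OC)c(-c2cc(-c3ccc(C(=O)N4CCC(C(F)(F)F)CC4)s3)on2)c1` carries 4-(trifluoromethyl)piperidin-1-yl in place of (cyclopropylmethyl)amino on a carbonyl carbon. Going by the values given here, no measured step gives a readable size for a change at this place and compound 3 starts from a limit, so for compound 4 in this assay the expected step is a number no higher from compound 3 to compound 4 (the limit leaves the size open), with no direction claimed beyond the scatter. Compound 4 is estimated at 30000 nM, within 10000 nM and 90000 nM.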

Compound 4, half-maximal inhibitory concentration: > 30000 nM
Compound 4: no number, only a limit (the forecaster's own chance of this, stated with the estimate: 60%); the middle value lies on the limit itself.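

No size can be read for the change from compound 3 to compound 4, because both compounds sit at the same limit and not at a number: the limit of > 30000 nM in this assay, at which 2 of the 4 values shown sit.

The compounds shown leave open how far any change on the carbonyl carbon moves the result in this assay.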